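A few compounds are considered here, and "the series" means these few. Any claim that something is new, unique, unknown or untested is made for them only; others in the source may bear on it.

Measured so far, in a functional assay on HepG2 cells (Homo sapiens) for antiproliferative activity, read by MTT assay, with a stated time of 48 h; on this read-out lower numbers stand for stronger inhibition and higher numbers for weaker inhibition:
compound 1 `Cc1ccc(N2CCN(Cn3nc(-c4ccc5c(c4)OCCO5)oc3=S)CC2)c(C)c1` — 28400 nM
compound 2 `Fc1ccccc1N1CCN(Cn2nc(-c3ccc4c(c3)OCCO4)oc2=S)CC1` — > 50000 nM, which is a limit of the assay and not a number
compound 3 `S=c1oc(-c2ccc3c(c2)OCCO3)nn1CN1CCN(c2cccc(Cl)c2)CC1` — > 50000 nM, which is a limit of the assay and not a number

Compound 3 thus stands only at a limit in this assay, as does one further compound in the set, see (the limit of > 50000 nM in this assay, at which 2 of the 3 values shown sit). Compound 1 alone gives a number. The steps of an at least 1.7-fold higher number from compound 1 to compound 2 (0.24 log units; that floor lies within the scatter) and an at least 1.7-fold higher number from compound 1 to compound 3 (0.24 log units; that floor lies within the scatter) are each known only as a floor, and that floor lies within the scatter. The step that the two limits leave unreadable from compound 2 to compound 3 cannot be read, since both ends are limits.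

Compound 4 `COc1cccc(N2CCN(Cn3nc(-c4ccc5c(c4)OCCO5)oc3=S)CC2)c1` differs from compound 3 by methoxy in place of chloro on an aromatic carbon. For the measured compounds named here, none of the measured steps changes only the group on an aromatic carbon of the aryl ring; all three swap the whole aryl group on the ring amine nitrogen, so no measured step bears directly on this change. Compound 1, with yet another aryl group, gives only 28400 nM. Against that background no step beyond the scatter is expected in this assay, and the expected step is a step that the limit leaves unreadable from compound 3 to compound 4. Compound 4 is accordingly estimated at 60000 nM, with a range from 20000 nM to 150000 nM, and most likely reported again only as a limit.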

Compound 4, half-maximal inhibitory concentration: 21400 nM
Estimate against measurement, compound 4: 2.8-fold (0.45 log units) above; measured number inside the range.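

In this assay, for the compounds shown here, methoxy in place of chloro gives an at least 2.3-fold lower number from compound 3 to compound 4 (0.36 log units; beyond the scatter), the first sign that the group on this aromatic carbon, meta to a large group, can by itself move the read-out out of the limit. That step and an at least 2.3-fold lower number from compound 2 to compound 4 (0.36 log units; beyond the scatter) are known only as floors, as compound 3 and compound 2 each stand only at a limit, and their full size stays hidden: the limit of > 50000 nM in this assay, at which 2 of the 4 values shown sit. The remaining step, a 1.3-fold lower number from compound 1 to compound 4 (0.12 log units; within the scatter), lies within the scatter, so 3-methoxyphenyl and 2,4-dimethylphenyl now stand as two different aryl groups on the ring amine nitrogen that give numbers of no readable difference in this series.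

The limits leave the step between the 2-fluorophenyl and 3-chlorophenyl compounds unreadable, and one change at one aromatic carbon does not say which feature of methoxy matters. Open too, as far as these compounds go, is whether a hydroxyl, an amine or a longer ether chain on the same carbon would carry the read-out further than methoxy does, or would fall back to the limit.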